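Vinyl to ethynyl on the ether chain of a brominated diphenyl ether

This account rests on a few compounds, and the source may have more. Where it says the series, first, only, none or still open, it means among the compounds named here.

Measured compounds in a functional assay on U-937 cells (Homo sapiens) for cytotoxicity, read by MTT assay, with a stated time of 24 h; on this read-out lower numbers stand for stronger inhibition and higher numbers for weaker inhibition:
Compound 1, `CC(C)(C)OC(=O)N1CCCN(CCCCCOc2c(Br)cc(Br)cc2Oc2ccc(Br)cc2Br)CC1`, gives 39.5 ug/mL.
Compound 2, `C=CCOc1c(Br)cc(Br)cc1Oc1ccc(Br)cc1Br`, gives 29 ug/mL.
Compound 3, `Brc1ccc(Oc2cc(Br)cc(Br)c2OCCCCCN2CCN(C/C=C/c3ccccc3)CC2)c(Br)c1`, gives 32.7 ug/mL.

All three share the same brominated diphenyl ether core and differ only in what hangs from the ether oxygen. Compound 2 carries the shortest group, an allyloxy chain. Its number sits close to those of compound 3 and compound 1; both gaps fall within the usual scatter of this read-out, so the three compounds cannot be told apart on these data.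

Compound 4, `C#CCOc1c(Br)cc(Br)cc1Oc1ccc(Br)cc1Br`, is the next step from compound 2: ethynyl in place of vinyl on a saturated chain carbon bound to an oxygen on an aromatic ring. Put another way, the allyloxy group becomes a propargyloxy group; the count of heavy atoms, donors and acceptors is unchanged.

For the measured compounds named here, no measured pair shows what such a swap does here. With so small a change, and with all measured numbers lying within the scatter of one another, the step of a 1.0-fold higher number from compound 2 to compound 4 (0.01 log units; within the scatter) is expected to stay within the scatter, with no clear direction. Compound 4 is therefore estimated at 30 ug/mL, with a range from 15 ug/mL to 60 ug/mL.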

Compound 4, half-maximal inhibitory concentration: 29.5 ug/mL
Compound 4: the middle estimate sits 1.0-fold (0.01 log units) above what was measured; the measured number falls inside the stated range.
By their numbers in this assay, from the lowest: compounds 2, 4, 3 and 1 (each within the scatter of the next).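

In this assay, for the compounds shown here, the first matched pair at this position, ethynyl in place of vinyl on a saturated chain carbon bound to an oxygen on an aromatic ring, gives a 1.0-fold higher number from compound 2 to compound 4 (0.01 log units; within the scatter). Going by these compounds alone, at this one place, then, the double bond and the triple bond cannot be told apart in this read-out, which the earlier compounds could not show because none of them formed such a pair. Nothing measured here offers an explanation for this outcome.

This is a single pair on a single core, so it does not show whether the same swap would behave alike elsewhere on the molecule. It also leaves open whether a saturated propyl group, a nitrile or a chain ending in a carboxylic acid on the same oxygen would move the number beyond the scatter.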